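From methoxycarbonyl to carboxy at the assay limit

The compounds below may be only part of what the source reports. "The series", "measured", "known", "first", "only" and "open" are said of these compounds alone.

Compound 1 `CCN(CC)CCNC(=O)c1ccc(C(CC)(CC)c2ccc(OCCC(O)(CC)CC)c(C)c2)n1CC`: 1630 nM
Compound 2 `CCC(C)C(NC(=O)c1ccc(C(CC)(CC)c2ccc(OCCC(O)(CC)CC)c(C)c2)n1CC)C(=O)OC`: > 50000 nM

These values come from a functional assay on Caco-2 cells (Homo sapiens) for antiproliferative activity, read by MTT assay, with a stated time of 48 h (a higher number here means a weaker inhibitor, a lower number a stronger inhibitor), and only the first is a number. Compound 2 gives > 50000 nM in this assay and this is a limit of the assay. Going by the values given here, the one measured step is an at least 30-fold higher number from compound 1 to compound 2 (1.48 log units; beyond the scatter) and it lies on an amide-type nitrogen, so it bears only loosely on the ester. Compound 3 `CCC(C)C(NC(=O)c1ccc(C(CC)(CC)c2ccc(OCCC(O)(CC)CC)c(C)c2)n1CC)C(=O)O` has not been measured. Its difference from compound 2 is hydrogen in place of methyl on an oxygen next to a carbonyl group and reads methoxycarbonyl to carboxy, with hydrogen in place of methyl on an oxygen next to a carbonyl group. Among the compounds with values here, no measured step touches this place. Given the limit of compound 2 at > 50000 nM in this assay no step beyond the scatter is expected, and a further limit is likely. On these data alone, the expected step is a step that the limit leaves unreadable from compound 2 to compound 3 and its direction stays open. The estimated value for compound 3 is 60000 nM with an expected range of 20000 nM to 150000 nM in this estimate.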

Compound 3, half-maximal inhibitory concentration: 20000 nM
Beside the measured number, compound 3's estimate is 3.0-fold (0.48 log units) above it; the range from low to high includes it.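

In this assay the change from methoxycarbonyl to carboxy moves compound 3 off the limit, and hydrogen in place of methyl on an oxygen next to a carbonyl group gives an at least 2.5-fold lower number from compound 2 to compound 3 (0.39 log units; beyond the scatter) at this place. The true size of that step cannot be read, since compound 2 has a limit and not a number: the limit of > 50000 nM in this assay, at which 1 of the 3 values shown sits. Even so, the 1-carboxy-2-methylbutyl group does not reach the level of the 2-(diethylamino)ethyl group on the amide-type nitrogen, the gap being a 12-fold higher number from compound 1 to compound 3 (1.09 log units; beyond the scatter) in this small set.

The compounds shown leave open whether a primary carboxamide or a tetrazole in place of the carboxy would keep this number. They also leave open whether an ethyl ester would sit at a limit as compound 2 does.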